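Swapping chloro for bromo on a pyridine ether ligand

This account rests on a few compounds, and the source may have more. Where it says the series, first, only, none or still open, it means among the compounds named here.

Measured so far: compound 1 `CN1CCC[C@H]1COc1cccnc1` gives 0.15 nM in an assay on membranes from brain for displacement of a labelled ligand from Neuronal acetylcholine receptor; alpha4/beta2 (Rattus norvegicus); a higher number here means a weaker inhibitor, a lower number a stronger inhibitor; compound 2 `CN1CCC[C@H]1COc1cncc(C(F)(F)F)c1` gives 1.83 nM; compound 3 `CN1CCC[C@H]1COc1cncc(Cl)c1` gives 0.6 nM.

Among these three, compound 3 stands second highest: the lower number belongs to compound 1, and the step of a 4.0-fold higher number from compound 1 to compound 3 (0.60 log units; beyond the scatter) lies beyond the scatter, while the step of a 3.1-fold lower number from compound 2 to compound 3 (0.48 log units; beyond the scatter) lies beyond the scatter in the other direction. Compound 4 `CN1CCC[C@H]1COc1cncc(Br)c1` differs from compound 3 in one place, (bromo in place of chloro on an aromatic carbon).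

Among the compounds with values here, two measured steps bear on this change, because both end at the same aromatic carbon of compound 3: a 4.0-fold higher number from compound 1 to compound 3 (0.60 log units; beyond the scatter), which shows that placing chloro where hydrogen stood raised the number, and a 3.1-fold lower number from compound 2 to compound 3 (0.48 log units; beyond the scatter), which shows that chloro gave a lower number than trifluoromethyl. Bromo is a single heavy atom like chloro, so the step in this assay is expected to be small, at most a slight rise, and likely within the scatter. The estimate for compound 4 is therefore 0.8 nM, within a range of 0.3 nM to 2.5 nM, which means an expected step of a 1.3-fold higher number from compound 3 to compound 4 (0.12 log units; within the scatter).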

Compound 4, inhibition constant: 0.27 nM
For compound 4 the middle estimate is 3.0-fold (0.47 log units) above the measured one; measured number outside the range, below it.
By their numbers in this assay, from the lowest: compounds 1 and 4 (each within the scatter of the next); then compound 3; then compound 2.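

At this aromatic carbon, two atoms from the ring nitrogen, chloro and bromo do not read alike: there is a 2.2-fold lower number from compound 3 to compound 4 (0.35 log units; beyond the scatter) when bromo takes the place of chloro, even though each is a single heavy atom. In this assay there is a 1.8-fold higher number from compound 1 to compound 4 (0.26 log units; within the scatter) when bromo replaces hydrogen, so this step cannot be told from the scatter, unlike the step from hydrogen to chloro; replacing trifluoromethyl with bromo gives a 6.8-fold lower number from compound 2 to compound 4 (0.83 log units; beyond the scatter) and is the larger gain of the two halogen swaps at this carbon. No measurement at hand explains why bromo and chloro differ here.

As far as these compounds go, whether iodo, methyl, methoxy or an amine at this carbon would also stay close to hydrogen remains open. From the compounds shown here alone, how bromo would fare on another carbon of the ring, or with a different core, also remains open.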